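This account rests on a few compounds, and the source may have more. Where it says the series, first, only, none or still open, it means among the compounds named here.

Measured in a functional assay (strain AB) with Danio rerio as the target, read by microscopy, with a stated time of 1 h; on this read-out higher numbers stand for an effect only at larger amounts of compound and lower numbers for an effect already at smaller amounts:
- Compound 1 `CCN1CCc2c(sc(NC(=O)Nc3ccccc3)c2C(N)=O)C1`: > 25000 nM
- Compound 2 `CC(C)[N+]1(C)CCc2c(sc(NC(=O)Nc3ccc(Cl)cc3)c2C(N)=O)C1`: 960 nM

Compound 1 has no exact number, only a limit of the assay (the limit of > 25000 nM in this assay, at which 1 of the 2 values shown sits).

Compound 3 `CCN1CCc2c(sc(NC(=O)NCC3CCCO3)c2C(N)=O)C1` is the next compound to follow. Its change from compound 1 is (oxolan-2-yl)methyl in place of phenyl on an amide-type nitrogen, with (oxolan-2-yl)methyl in place of phenyl on an amide-type nitrogen. Among the measured compounds shown here, no measured pair isolates this change.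

In this assay, no step beyond the scatter is expected, and the estimate is a number no higher from compound 1 to compound 3 (the limit leaves the size open).

For compound 3, the expected value is 25000 nM, with an estimated range of 8000 nM to 50000 nM.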

Compound 3, half-maximal effective concentration: > 25000 nM
Compound 3: a limit, no number; the forecaster's own chance of this, stated with the estimate: 75%; the middle value sits exactly at the limit.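

Compound 1 and compound 3 both stop at a limit, so no step can be read between them: the limit of > 25000 nM in this assay, at which 2 of the 3 values shown sit.

On these data alone, whether (oxolan-2-yl)methyl in place of phenyl on an amide-type nitrogen changes the effect at all stays open.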